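A few compounds are considered here, and "the series" means these few. Any claim that something is new, unique, unknown or untested is made for them only; others in the source may bear on it.

Compound 1 `COc1ccccc1CNc1nc(Nc2ccc(N3CCN(C)CC3)cn2)ncc1Cl`: 29300 nM
Compound 2 `CC(C)c1ccc(Nc2nc(Nc3ccc(N4CCN(C)CC4)cn3)ncc2Cl)cc1`: 7020 nM

Among the compounds with values here, in a functional assay on MDA-MB-231 cells (Homo sapiens) for inhibition, read by CCK-8 assay, with a stated time of 48 h (on this read-out higher numbers stand for weaker inhibition of growth and lower numbers for stronger inhibition of growth), compound 2 gives 7020 nM, the lower of the two numbers so far. Compound 3 `CN1CCN(c2ccc(Nc3ncc(Cl)c(Nc4ccc(C(C)(C)C)cc4)n3)nc2)CC1` carries methyl in place of hydrogen on a saturated chain carbon bound to an aromatic carbon and two saturated chain carbons, turning isopropyl into tert-butyl. Within the data shown here, the only measured step with any bearing is a 4.2-fold lower number from compound 1 to compound 2 (0.62 log units; beyond the scatter), and it swaps a whole group, so it is a loose guide for a change this small. No large move is therefore expected, only a slight lean towards a lower number. The expected step is a 1.3-fold lower number from compound 2 to compound 3 (0.11 log units; within the scatter). For compound 3 the estimate is 5500 nM, with an expected range of 2000 nM to 14000 nM.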

Compound 3, concentration for 50% growth inhibition: 16200 nM
Estimate against measurement, compound 3: 2.9-fold (0.47 log units) below, and the stated range ends below it.
By their numbers in this assay, from the lowest: compound 2; then compounds 3 and 1 (each within the scatter of the next).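

In this assay, a single added methyl on the saturated chain carbon bound to an aromatic carbon and two saturated chain carbons is enough to shift the number (a 2.3-fold higher number from compound 2 to compound 3 (0.36 log units; beyond the scatter)), so isopropyl to tert-butyl is not a silent change here. With 4-(tert-butyl)phenyl, the step from 2-methoxybenzyl stays within the scatter (a 1.8-fold lower number from compound 1 to compound 3 (0.26 log units; within the scatter)). Nothing available explains the shift. Open, on these data alone, is how the number moves with ethyl, cyclopropyl or a carboxylic acid in place of isopropyl.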